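Aryl substituent series: ethyl to tert-butyl

The source may report more compounds than this note shows. Statements on the series, on what has been measured and on what is new or still open speak of the compounds shown alone.

Measured so far in a functional assay on XF498 cells (Homo sapiens) for antiproliferative activity, read by MTT assay, with a stated time of 96 h; a lower number here means a stronger inhibitor, a higher number a weaker inhibitor:
- compound 1 `O=C1NN(c2ccc([N+](=O)[O-])cc2)C(=O)C2(CSC3=C2C(=O)c2ncccc2C3=O)N1`: 4800 nM
- compound 2 `CCc1ccc(N2C(=O)NC3(CSC4=C3C(=O)c3ncccc3C4=O)C2=O)cc1`: 1200 nM

Compound 2 holds the lower of the two numbers in this assay; compound 1 gives a higher number, and the gap between compound 1 and compound 2 lies beyond the scatter. These two compounds differ in more than one place, so no single step can be read from them.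

Compound 3 `CC(C)(C)c1ccc(N2C(=O)NC3(CSC4=C3C(=O)c3ncccc3C4=O)C2=O)cc1` keeps the shared core of compound 2 and changes only the substituent on the aryl ring: tert-butyl in place of ethyl on an aromatic carbon. The ethyl and tert-butyl groups are both small saturated carbon chains without donors, acceptors or charge. Nothing measured here shows how such a change moves the number, so no step beyond the scatter is expected in either direction; the estimated step of a 1.2-fold lower number from compound 2 to compound 3 (0.08 log units; within the scatter) is taken as small. For compound 3 the expected value is 1000 nM, with a range from 400 nM to 3000 nM.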

Compound 3, half-maximal inhibitory concentration: 850 nM
Compound 3: the middle estimate sits 1.2-fold (0.07 log units) above what was measured, and the stated range covers the measured number.
By their numbers in this assay, from the lowest: compounds 3 and 2 (each within the scatter of the next); then compound 1.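

At this position, on an aromatic carbon para to a large group, tert-butyl in place of ethyl gives a 1.4-fold lower number from compound 2 to compound 3 (0.15 log units; within the scatter) in this assay. Among the compounds shown here, this is the first single-place comparison, and it shows that the 4-ethylphenyl and 4-(tert-butyl)phenyl compounds cannot be told apart in this read-out, so the position accepts either saturated carbon group with no step beyond the scatter. Nothing available speaks to what lies behind this result.

For the compounds shown here, compound 1 differs from compound 2 in more than one place, so no step involving compound 1 can be read. From the compounds shown here alone, whether an amine, a carboxylic acid, a methoxy group or a longer chain at this same position would move the number beyond the scatter remains open.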